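The compounds below may be only part of what the source reports. "The series", "measured", "known", "first", "only" and "open" are said of these compounds alone.

Working notes on the series, cytotoxicity read-out.

Measured compounds in an ADME assay on TZM cells (Homo sapiens) for cytotoxicity, with a stated time of 1 days; on this read-out lower numbers stand for higher toxicity in this test and higher numbers for lower toxicity in this test:
- compound 1 `COCCNC(=O)/C=C/c1cnc(Nc2ccc(C#N)cc2)nc1Oc1c(C)cc(C#N)cc1C`: > 213 nM, a limit of the test.
- compound 2 `Cc1cc(C#N)cc(C)c1Oc1nc(Nc2ccc(C#N)cc2)ncc1/C=C/C(=O)NCCOCCO`: > 200 nM, a limit of the test.
- compound 3 `Cc1cc(C#N)cc(C)c1Oc1nc(Nc2ccc(C#N)cc2)ncc1/C=C/C(=O)NCC1CCN(S(C)(=O)=O)C1`: > 175 nM, a limit of the test.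

Among the compounds with values here, compound 3 stands at a limit in this assay, as do the other two values shown; no compound has a number. The steps among them, a step that the two limits leave unreadable from compound 1 to compound 2, a step that the two limits leave unreadable from compound 1 to compound 3 and a step that the two limits leave unreadable from compound 2 to compound 3, are all unreadable, each resting on two limits (the limit of > 175 nM in this assay, at which 1 of the 3 values shown sits, (the limit of > 200 nM in this assay, at which 1 of the 3 values shown sits), (the limit of > 213 nM in this assay, at which 1 of the 3 values shown sits)).

Compound 4 `Cc1cc(C#N)cc(C)c1Oc1nc(Nc2ccc(C#N)cc2)ncc1/C=C/C(=O)N1CCN(S(C)(=O)=O)CC1` differs from compound 3 in one place: 4-(methylsulfonyl)piperazin-1-yl in place of ((1-(methylsulfonyl)pyrrolidin-3-yl)methyl)amino on a carbonyl carbon. Within the data shown here, the steps that bear on it are those that changed the amide substituent, from compound 1 to compound 3 and from compound 2 to compound 3; both left the read-out at a limit, so they give no size and no direction. The change from compound 3 to compound 4 is therefore expected to give no step beyond the scatter in this assay, with the value most likely remaining a limit; the expected step is a step that the limit leaves unreadable from compound 3 to compound 4. Compound 4 is estimated at 300 nM, with a range from 150 nM to 2000 nM.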

Compound 4, half-maximal cytotoxic concentration: > 179 nM
Compound 4: no number, only a limit; the forecaster's own chance of this, stated with the estimate: 80%; the middle value does not contradict the limit.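

Compound 4 gives > 179 nM in this assay as a limit of the test, so its steps from compound 1, compound 2 and compound 3 cannot be read, each resting on two limits. The compounds shown leave open whether any of these amide substituents changes the half-maximal cytotoxic concentration, as none of the four has a number.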